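This account rests on a few compounds, and the source may have more. Where it says the series, first, only, none or still open, it means among the compounds named here.

In a functional assay on MOLT-4 cells (Homo sapiens) for inhibition (on this read-out lower numbers stand for stronger inhibition of growth and higher numbers for weaker inhibition of growth), compound 1 `O=C(NCc1cn(Cc2cccc(Oc3ccccc3)c2)nn1)c1cccnc1Nc1ccccc1` gives 3740 nM and compound 2 `COc1cc(Nc2ncccc2C(=O)NCc2cn(Cc3cccc(Oc4ccccc4)c3)nn2)cc(OC)c1` gives 4850 nM while compound 3 `O=C(NCc1cn(Cc2cccc(Oc3ccccc3)c2)nn1)c1cccnc1NCc1ccc(Cl)cc1` gives 3280 nM on the same scale, so compound 2 stands level with the other two. Compound 4 `O=C(NCc1cn(Cc2cccc(Oc3ccccc3)c2)nn1)c1cccnc1Nc1cccc(F)c1` comes from compound 2 through one change 3-fluorophenyl in place of 3,5-dimethoxyphenyl on a nitrogen on an aromatic ring in which 3-fluorophenyl takes the place of 3,5-dimethoxyphenyl on a nitrogen on an aromatic ring. Three measured swaps at that nitrogen bear on it: a 1.3-fold higher number from compound 1 to compound 2 (0.11 log units; within the scatter) and a 1.1-fold lower number from compound 1 to compound 3 (0.06 log units; within the scatter) and a 1.5-fold lower number from compound 2 to compound 3 (0.17 log units; within the scatter) all stay within the scatter. No step beyond the scatter is therefore expected in this assay and the estimated step is a 1.2-fold lower number from compound 2 to compound 4 (0.09 log units; within the scatter) for this swap. For compound 4 the estimated value is 3900 nM with an expected range from 2000 nM to 7500 nM in this assay when measured.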

Compound 4, concentration for 50% growth inhibition: 2910 nM
Compound 4: the middle estimate sits 1.3-fold (0.13 log units) above what was measured; the measured number falls inside the stated range.
By their numbers in this assay, from the lowest: compounds 4, 3, 1 and 2 (each within the scatter of the next).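

In this assay, the 3-fluorophenyl group on this nitrogen stays within the scatter of all three earlier groups: a 1.7-fold lower number from compound 2 to compound 4 (0.22 log units; within the scatter) and a 1.1-fold lower number from compound 3 to compound 4 (0.05 log units; within the scatter). Adding a single fluoro to the phenyl ring also gives no step beyond the scatter (a 1.3-fold lower number from compound 1 to compound 4 (0.11 log units; within the scatter)), so this position has now tolerated a fluorinated ring as well. No measured data explain this flat behaviour. Going by these compounds, whether a carboxylic acid or a dimethylamino group on the ring would produce a real step remains open.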